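The compounds below may be only part of what the source reports. "The series", "measured", "known", "first", "only" and "open" are said of these compounds alone.

The measured compounds are:
compound 1, `O=C1CCC(/C=C/c2ccc(-c3ccccc3)cc2)=NN1`, which gives 24.6 umol/kg in a functional assay on the whole organism for inhibition, with Rattus norvegicus as the target, read by paw edema, with a stated time of 4 h; a lower number here means that less compound is needed, a higher number that more compound is needed for the effect;
compound 2, `CN1N=C(/C=C/c2ccc(-c3ccccc3)cc2)CCC1=O`, which gives 32.4 umol/kg in this assay;
compound 3, `O=C1CCC(CCc2ccc(-c3ccccc3)cc2)=NN1`, which gives 18.7 umol/kg in this assay.

Compound 1 and compound 2 share a core and differ by a single change, (methyl in place of hydrogen on an amide-type nitrogen in a ring). The measured step, a 1.3-fold higher number from compound 1 to compound 2 (0.12 log units; within the scatter), is small. Compound 3 carries a different linker between the ring system and the biphenyl portion; the difference between the core of compound 1 and that of compound 3 is not broken down here. Compound 3 gives a number close to that of compound 1, and also close to that of compound 2, so the three measured compounds sit near one another.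

Compound 4, `CN1N=C(CCc2ccc(-c3ccccc3)cc2)CCC1=O`, has not yet been measured in this assay. It differs from compound 3 by methyl in place of hydrogen on an amide-type nitrogen in a ring. This is the same change seen once already among these compounds, made at the same place on the same kind of ring, and it is now applied to the saturated-linker core instead of the unsaturated one.

Among the compounds with values here, for compound 4 the expected step is a 1.3-fold higher number from compound 3 to compound 4 (0.11 log units; within the scatter), resting on the single earlier instance of this change, a 1.3-fold higher number from compound 1 to compound 2 (0.12 log units; within the scatter), which stayed small. Compound 4 is accordingly estimated at 24 umol/kg, with a plausible range from 12 umol/kg to 48 umol/kg.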

Compound 4, dose for half-maximal effect: 22.3 umol/kg
Compound 4: the middle estimate sits 1.1-fold (0.03 log units) above what was measured; the range from low to high includes it.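

In this assay, methyl in place of hydrogen on an amide-type nitrogen in a ring gives a 1.2-fold higher number from compound 3 to compound 4 (0.08 log units; within the scatter), which is again a small step, this time on the core with the saturated linker. Set beside the earlier step on the unsaturated core, the change reads alike on both cores: the same change on two cores in this assay, a 1.3-fold higher number (0.12 log units; within the scatter) from compound 1 to compound 2 and a 1.2-fold higher number (0.08 log units; within the scatter) from compound 3 to compound 4, 1.1-fold (0.04 log units) apart, within the scatter of two such steps. Within the data shown here, this shows that the change can be carried between these two cores without the step leaving the scatter, but it rests on only two pairs, and since both steps lie within the scatter, it does not show that the methyl shifts the number in any direction, nor that the same would hold on a core beyond these two.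

The compounds shown carry only hydrogen or methyl on that nitrogen, so an ethyl group, a longer chain or a carboxylic acid in that place remains open, as does any linker other than the two seen here. As far as these compounds go, the biphenyl portion is the same in all four compounds, so how an amine or a carboxylic acid on that portion would read in this assay also stays open.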